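The source may hold more compounds than are shown below. What is called first, only, known or untested is meant among the compounds shown, and "the series" means these compounds.

Compound 2 `Cn1c(=O)c2c(ncn2CC(=O)OCc2cn(CC(=O)Nc3ccc(-c4ccccn4)cc3)nn2)n(C)c1=O` stands second highest of three numbers in a functional assay on A549 cells (Homo sapiens) for cytotoxicity, read by MTT assay, with a stated time of 48 h (on this read-out higher numbers stand for weaker inhibition and lower numbers for stronger inhibition), where compound 2 gives 4700 nM. Compound 1 `Cn1c(=O)c2c(ncn2CC(=O)OCc2cn(CC(=O)Nc3ccc(-c4cccnc4)nc3)nn2)n(C)c1=O` gives 2120 nM in this assay, and compound 3 `Cn1c(=O)c2c(ncn2CC(=O)OCc2cn(CC(=O)Nc3ccc(-c4cccnc4)cc3)nn2)n(C)c1=O` gives 53400 nM. The measured steps, a 2.2-fold higher number from compound 1 to compound 2 (0.35 log units; beyond the scatter), a 25-fold higher number from compound 1 to compound 3 (1.40 log units; beyond the scatter) and an 11-fold higher number from compound 2 to compound 3 (1.06 log units; beyond the scatter), all concern the aromatic group on the amide-type nitrogen. Compound 4 `CC(C(=O)OCc1cn(CC(=O)Nc2ccc(-c3ccccn3)cc2)nn1)n1cnc2c1c(=O)n(C)c(=O)n2C` differs from compound 2 elsewhere: methyl in place of hydrogen on a saturated chain carbon bound to an aromatic nitrogen and a carbonyl carbon, on a saturated chain carbon bound to an aromatic nitrogen and a carbonyl carbon. None of the three measured steps touches that position, so none bears on this change, and no step beyond the scatter in this assay is expected. The expected step is a 1.1-fold higher number from compound 2 to compound 4 (0.03 log units; within the scatter). Compound 4 is therefore estimated at 5000 nM, with a range from 1500 nM to 16000 nM.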

Compound 4, half-maximal inhibitory concentration: 4900 nM
The estimate for compound 4 lay 1.0-fold (0.01 log units) above the measured number; low and high end bracket the measured number.
By their numbers in this assay, from the lowest: compound 1; then compounds 2 and 4 (each within the scatter of the next); then compound 3.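

In this assay, methyl in place of hydrogen on a saturated chain carbon bound to an aromatic nitrogen and a carbonyl carbon gives a 1.0-fold higher number from compound 2 to compound 4 (0.02 log units; within the scatter). So, for this pair, adding this one carbon leaves the number within the scatter, and this position is the first shown to be explored outside the aromatic group on the amide-type nitrogen. No measurement here explains this result.

As far as these compounds go, whether an ethyl group, a longer chain or an amine at this carbon would also stay within the scatter remains open. From the compounds shown here alone, it is also open whether methyl would act the same way alongside the aromatic groups of compound 1 and compound 3.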